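The source may hold more compounds than are shown below. What is called first, only, known or untested is meant among the compounds shown, and "the series" means these compounds.

Working notes on the sulfamate series.

Compound 1 `CC(C)CCN(CCC(C)C)c1ccc(C(=O)N2CCc3ccc(OS(N)(=O)=O)cc3C2)cc1` is one of two measured members. In a physicochemical assay for lipophilicity (a higher number here means a more lipophilic compound, a lower number a more polar compound), compound 1 gives 1.93. The other measured member, compound 2 `CN(C)CCCN(Cc1ccccc1)c1ccc(C(=O)N2CCc3ccc(OS(N)(=O)=O)cc3C2)cc1`, gives in this assay a value of 1.93, which at the digits shown is level with compound 1 and within the usual scatter of the method; nothing of order can be read between the two. Within the data shown here, no pair of measured compounds differing in a single place is available, so no measured step exists to lean on.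

The next member is compound 3 `CCN(Cc1cccc(Br)c1)c1ccc(C(=O)N2CCc3ccc(OS(N)(=O)=O)cc3C2)cc1`, not yet measured in this assay. Its relation to compound 1 is a single exchange: (3-bromobenzyl)(ethyl)amino in place of diisopentylamino on an aromatic carbon. The departing group and the arriving group carry the same count of heavy atoms; the arriving one brings a six-membered aromatic ring of carbon only and a bromine in place of two branched alkyl chains, on an aromatic carbon para to a large group.

Among the measured compounds shown here, with no measured step for guidance, the expected step of a number 0.18 log units lower from compound 1 to compound 3 (within the scatter) is small and downward, perhaps not beyond the scatter. For compound 3 the estimate in this assay is 1.75, expected to lie between 1.2 and 2.3.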

Compound 3, partition coefficient: 1.93
Compound 3: the middle estimate sits 0.18 log units below what was measured, and the stated range covers the measured number.
By their numbers in this assay, from the lowest: compounds 1, 2 and 3 (each within the scatter of the next).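

The series now holds a measured step in a single place: in this assay, (3-bromobenzyl)(ethyl)amino in place of diisopentylamino on an aromatic carbon para to a large group gives no change at the digits printed from compound 1 to compound 3 (within the scatter). At this position, a group with two branched alkyl chains and a group with a six-membered aromatic ring of carbon only and a bromine, both with the same count of heavy atoms, are therefore not separated by this assay. No measured evidence bears on this level reading.

The compounds shown leave open whether the reading would hold for a group of a different kind at the same aromatic carbon, such as a carboxylic acid or a primary amine, or for a much smaller group such as dimethylamino. Also open, on these data alone, is what benzyl(ethyl)amino, without the bromine, would give in this assay, so the bromine and the rest of the entering group cannot yet be read apart.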